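Two Amine Acids of a Shared Core and a Combined Analogue

The source may hold more compounds than are shown below. What is called first, only, known or untested is meant among the compounds shown, and "the series" means these compounds.

Compound 1 `C/C=C(\C(=O)O)C(NCc1ccc(N)cc1)C(C)C`: 9800 nM
Compound 2 `C/C=C(\C(=O)NCC(=O)O)C(C)NCc1ccc(N)cc1`: 9800 nM

In an assay on a protein complex (K562 cells) for inhibition of integrin alpha-5/beta-1 (Homo sapiens), with stated times of 30 min and 1 h (a lower number here means a stronger inhibitor, a higher number a weaker inhibitor), compound 1 gives 9800 nM. In this assay compound 2 gives 9800 nM and so stands level with compound 1, within the usual scatter. Compound 3 `C/C=C(\C(=O)NCC(=O)O)C(NCc1ccc(N)cc1)C(C)C` differs from compound 2 by isopropyl in place of methyl on a saturated chain carbon bound to an amine nitrogen and a double-bonded chain carbon. Within the data shown here, no measured pair shows this change, so its size is unknown. Compound 3 is expected to stay near compound 2, with the step from a 1.4-fold lower number from compound 2 to compound 3 (0.15 log units; within the scatter) expected not to exceed the scatter in either direction. The estimate for compound 3 is 7000 nM, ranging from 2500 nM to 20000 nM.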

Compound 3, half-maximal inhibitory concentration: 220 nM
Compound 3: middle estimate off by 32-fold (1.50 log units), on the high side; measured number outside the range, below it.
By their numbers in this assay, from the lowest: compound 3; then compounds 1 and 2 (each within the scatter of the next).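

In this assay, isopropyl in place of methyl on a saturated chain carbon bound to an amine nitrogen and a double-bonded chain carbon gives a 45-fold lower number from compound 2 to compound 3 (1.65 log units; beyond the scatter) and so shows that this position matters when the (carboxymethyl)amino group is present. That group in place of hydroxy on a carbonyl carbon gives a 45-fold lower number from compound 1 to compound 3 (1.65 log units; beyond the scatter) when isopropyl is present, so the two groups together achieve what the level pair, compound 1 and compound 2, did not reveal. No measurement here explains this gain.

On these data alone, whether an ethyl or cyclohexyl group at that chain carbon would keep the gain remains open. So does the effect of a longer chain in place of the (carboxymethyl)amino group.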